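The source may report more compounds than this note shows. Statements on the series, on what has been measured and on what is new or still open speak of the compounds shown alone.

In a functional assay on BaF3 cells (Mus musculus) for inhibition, read by CCK-8 assay, with a stated time of 72 h (a lower number here means a stronger inhibitor of growth, a higher number a weaker inhibitor of growth), compound 2 `Cc1ccc(NC(=O)Nc2ccc(Oc3cc(N)ncn3)cc2)cc1C(F)(F)F` stands at > 10000 nM, which is a limit of the assay and not a number. Compound 3 `CNCCN(C)c1cc(Oc2ccc(NC(=O)Nc3ccc(C)c(C(F)(F)F)c3)cc2)ncn1` gives > 10000 nM, also a limit. The series therefore has (the limit of > 10000 nM in this assay, at which 2 of the 3 values shown sit). Only compound 1 `Cc1ccc(NC(=O)Nc2ccc(Oc3cc(NCc4ccccc4)ncn3)cc2)cc1C(F)(F)F` gives a number, 3010 nM.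

Compound 4 `COCCNc1cc(Oc2ccc(NC(=O)Nc3ccc(C)c(C(F)(F)F)c3)cc2)ncn1` has 2-methoxyethyl in place of hydrogen on a nitrogen on an aromatic ring of compound 2: 2-methoxyethyl in place of hydrogen on a nitrogen on an aromatic ring.

Within the data shown here, three measured steps bear on this change. Replacing benzyl with hydrogen gives an at least 3.3-fold higher number from compound 1 to compound 2 (0.52 log units; beyond the scatter), so hydrogen on that nitrogen does worse than benzyl. Replacing benzylamino with methyl(2-(methylamino)ethyl)amino gives an at least 3.3-fold higher number from compound 1 to compound 3 (0.52 log units; beyond the scatter). The last comparison is a step that the two limits leave unreadable from compound 2 to compound 3, so compound 3 shows no readable gain over the unsubstituted amino group. The new group in compound 4 has no ring, and compound 3 warns against expecting much from such a chain.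

The expected change, an at least 1.1-fold lower number from compound 2 to compound 4 (0.04 log units; that floor lies within the scatter), is small and leans toward a lower number, though it may remain unreadable. For compound 4 the estimated value is 9000 nM, with an expected range of 3000 nM to 25000 nM.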

Compound 4, concentration for 50% growth inhibition: 7950 nM
Beside the measured number, compound 4's estimate is 1.1-fold (0.05 log units) above it; low and high end bracket the measured number.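

On this nitrogen, a chain without a ring can give a readable number in this assay, with an at least 1.2-fold lower number from compound 2 to compound 4 (0.09 log units; that floor lies within the scatter) and an at least 1.2-fold lower number from compound 3 to compound 4 (0.09 log units; that floor lies within the scatter). Both floors lie within the scatter, and the true size of these two gains cannot be read, since each starts from a limit and not a number: the limit of > 10000 nM in this assay, at which 2 of the 4 values shown sit.

Benzyl still does better than the 2-methoxyethyl chain, with a 2.6-fold higher number from compound 1 to compound 4 (0.42 log units; beyond the scatter), so a ring on this nitrogen is not needed for a measurable value, but the one ring shown here gives the lower number.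

Still open, going by these compounds, is whether the oxygen in the chain matters, which a plain butyl chain would test. Also open, on these data alone, is whether a phenethyl or pyridylmethyl group on the same nitrogen would do better than benzyl.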